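Cytotoxicity working notes: from compound 2 toward compound 4

A few compounds are considered here, and "the series" means these few. Any claim that something is new, unique, unknown or untested is made for them only; others in the source may bear on it.

Three compounds of the series have been run in an ADME assay on Vero cells (Chlorocebus sabaeus) for cytotoxicity, read by resazurin assay, with a stated time of 3 days; on this read-out higher numbers stand for weaker inhibition and lower numbers for stronger inhibition. Compound 1 `O=C(NCc1ccccc1)Nc1cc2nc(C3CCCCC3)[nH]c2cc1N1CCCC1` gives > 100 ug/mL, which is a limit of this assay rather than a number. Compound 2 `CCN(CC)c1cc2[nH]c(C3CCCCC3)nc2cc1NC(=O)c1ccc(OC(F)F)cc1` gives > 100 ug/mL, again a limit. Compound 3 `CN(C)c1cc2[nH]c(C3CCCCC3)nc2cc1NC(=O)c1ccc(OC(F)F)cc1` gives > 100 ug/mL, also a limit. Within the data shown here, the only step between measured compounds that differ in a single place, dimethylamino in place of diethylamino on an aromatic carbon, reads a step that the two limits leave unreadable from compound 2 to compound 3. Compound 2 therefore stands only at a limit in this assay, and the two further values are limits as well. What the series shows so far is the limit of > 100 ug/mL in this assay, at which 3 of the 3 values shown sit.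

Compound 4 `CCN(CC)c1cc2[nH]c(C3CCCCC3)nc2cc1NC(=O)c1ccc(C)cc1` differs from compound 2 by methyl in place of difluoromethoxy on an aromatic carbon. Among the measured compounds shown here, no measured step touches this position, and the single step that exists, from compound 2 to compound 3, is unreadable, so nothing measured sets a size or direction for the present change. With every value sitting at the limit, no step beyond the scatter is expected in this assay in either direction. The expected step is a step that the limit leaves unreadable from compound 2 to compound 4. Compound 4 is accordingly expected to sit at or near the limit, estimated at 150 ug/mL with a range from 70 ug/mL to 400 ug/mL.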

Compound 4, half-maximal inhibitory concentration: > 100 ug/mL
Compound 4: no number, only a limit; the forecaster's own chance of this, stated with the estimate: 85%; the middle value does not contradict the limit.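

No step can be read from compound 2 to compound 4, as both stand only at a limit, and the series stays as it was: the limit of > 100 ug/mL in this assay, at which 4 of the 4 values shown sit.

The compounds shown leave open what number any of them would give in this assay, and so whether methyl in place of difluoromethoxy on the aromatic carbon changes the read-out at all.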